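This account rests on a few compounds, and the source may have more. Where it says the series, first, only, none or still open, it means among the compounds named here.

Among the compounds with values here, compound 2 `COc1cc(/C=C/C(=O)c2ccc(NC(=O)CN3CCN(c4cc5c(cc4F)c(=O)c(C(=O)O)cn5C4CC4)CC3)cc2)cc(OC)c1OC` is one of two compounds measured in an assay on isolated protein for inhibition of DNA topoisomerase 1 (Homo sapiens), with a stated time of 30 min, tested at 20 uM; on this read-out higher numbers stand for a stronger effect at the one concentration tested and lower numbers for a weaker effect. In this assay compound 2 gives 11.5%, the larger of the two numbers, though its lead is within the scatter; compound 1 `O=C(CN1CCN(c2cc3c(cc2F)c(=O)c(C(=O)O)cn3C2CC2)CC1)Nc1ccc(C(=O)/C=C/c2cccc(Cl)c2)cc1` gives 3.1% in this assay, and the difference is a number 8.4 percentage points higher from compound 1 to compound 2 (within the scatter). Compound 3 `O=C(CN1CCN(c2cc3c(cc2F)c(=O)c(C(=O)O)cn3C2CC2)CC1)Nc1ccc(C(=O)/C=C/c2cccc([N+](=O)[O-])c2)cc1` has not yet been measured in this assay. The change that turns compound 2 into compound 3 is 3-nitrophenyl in place of 3,4,5-trimethoxyphenyl on a double-bonded chain carbon bound to a double-bonded chain carbon. Within the data shown here, only one measured step bears on it: the step of a number 8.4 percentage points higher from compound 1 to compound 2 (within the scatter), which also exchanged the group on a double-bonded chain carbon bound to a double-bonded chain carbon, and which stayed within the scatter. With nothing else to go on, no step beyond the scatter is expected in this assay in either direction. The number expected for compound 3 in this assay is 7%, with a range from 0% to 20%. This expectation amounts to a step of a number 4.5 percentage points lower from compound 2 to compound 3 (within the scatter), estimated to lie within the scatter.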

Compound 3, a percentage reported as inhibition, at one concentration (the size of the read-out at that concentration, not a potency): 11.1%
Compound 3: middle estimate off by 4.1 percentage points, on the low side, and the stated range covers the measured number.
By their numbers in this assay, from the lowest: compounds 1, 3 and 2 (each within the scatter of the next).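

Putting 3-nitrophenyl in place of 3,4,5-trimethoxyphenyl on a double-bonded chain carbon bound to a double-bonded chain carbon gives a number 0.4 percentage points lower from compound 2 to compound 3 (within the scatter) in this assay and nitro in place of chloro on an aromatic carbon gives a number 8 percentage points higher from compound 1 to compound 3 (within the scatter) on the same read-out. The earlier compounds shown here offered a single exchange at this place, whereas three groups can now be compared there, and no step among them leaves the scatter, so this read-out does not separate the chloro, nitro and trimethoxy variants. Nothing measured here accounts for how close these numbers lie.

Going by these compounds, all three groups are substituted phenyl rings, so it remains open what an amine, a carboxylic acid or an unsubstituted phenyl would give at this place in this assay on the otherwise unchanged compound. On these data alone, it also remains open whether a change elsewhere, such as a longer chain in place of the one joining the shared core to the aromatic ring, would produce a step beyond the scatter.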